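The source may hold more compounds than are shown below. What is called first, only, known or untested is meant among the compounds shown, and "the series" means these compounds.

Compound 2 `CC1(C)Cc2c(ccc(C(=O)/C=C/c3ccccc3)c2OCc2ccccc2)O1` is the starting point of this comparison, and its standing is known only as a boundary. In a functional assay on HT-29 cells (Homo sapiens) for antiproliferative activity, read by MTT assay, with a stated time of 48 h (a lower number here means a stronger inhibitor, a higher number a weaker inhibitor), compound 2 gives > 100000 nM, which is a limit of the assay and not a measured number. Compound 1 `CC1(C)Cc2c(ccc(C(=O)/C=C/c3cn(-c4ccccc4)nc3-c3cccc([N+](=O)[O-])c3)c2OCc2ccccc2)O1` in this assay gives > 100000 nM, again a limit. Compound 3 `CC1(C)Cc2c(ccc(C(=O)/C=C/c3cn(-c4ccccc4)nc3-c3ccc(Cl)cc3)c2OCc2ccccc2)O1` in this assay gives > 100000 nM, once more a limit. Within the data shown here, the step that the two limits leave unreadable from compound 1 to compound 3 therefore cannot be read, and the limit of > 100000 nM in this assay, at which 3 of the 3 values shown sit, shows that every value so far rests at the same boundary. Compound 4 `CC1(C)Cc2c(ccc(C(=O)/C=C/c3ccc(Cl)cc3)c2OCc2ccccc2)O1` differs from compound 2 by chloro in place of hydrogen on an aromatic carbon. Among the measured compounds shown here, no measured step mirrors this change on the shared core, and the one measured step is unreadable, so there is no basis for expecting a readable move in either direction. Compound 4 is expected to show a step that the limit leaves unreadable from compound 2 to compound 4. Compound 4 is expected to give 150000 nM in this assay, with a range from 50000 nM to 500000 nM, most probably reported again as a limit.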

Compound 4, half-maximal inhibitory concentration: > 100000 nM
Compound 4 gave a limit, no number (the forecaster's own chance of this, stated with the estimate: 80%); the middle value lies beyond the limit too.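

Compound 2 and compound 4 both stand at a limit and not at a number, so no step can be read between them: the limit of > 100000 nM in this assay, at which 4 of the 4 values shown sit.

The compounds shown leave open whether any change on the shared core would give a measured number in this assay.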